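Methoxy on the benzyl ring of a propargylamine thioether

A few compounds are considered here, and "the series" means these few. Any claim that something is new, unique, unknown or untested is made for them only; others in the source may bear on it.

Compound 2, `C#CCNC1CCc2c(SCc3ccccc3)cccc21`, carries an unsubstituted benzyl thioether on the shared core. In an ADME assay on isolated protein for inhibition of Amine oxidase [flavin-containing] B (Homo sapiens) (on this read-out higher numbers stand for weaker inhibition and lower numbers for stronger inhibition), compound 2 is recorded only as "not active" (no number reported), with no number behind it, so it stands at the weak end of what this series shows. Its closest measured relative is compound 1, `C#CCNC1CCc2c(SCc3ccc(Br)cc3)cccc21`, whose bromine on the benzyl ring goes with an activity in this assay of 488 nM. Compound 3, `C#CCNC1CCc2c(SCc3cccc(OC)c3)cccc21`, remains to be measured; it differs from compound 2 by methoxy in place of hydrogen on an aromatic carbon. For the measured compounds named here, since no step between measured compounds is available for this change, the expected direction rests on compound 2 alone: some gain in inhibition seems possible, but it is expected to stay modest and uncertain in size. Compound 3 is therefore expected to give about 3000 nM in this assay, with a plausible range of 600 nM to 20000 nM.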

Compound 3, half-maximal inhibitory concentration: 1520 nM
The estimate for compound 3 lay 2.0-fold (0.30 log units) above the measured number; the measured number falls inside the stated range.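

For the compounds shown here, compound 2 has no number in this assay, and no step from it to compound 3 can be read. The compounds shown leave open how large a change methoxy in place of hydrogen brings on the shared core. No supporting data bear on the value of compound 3.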